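The source may report more compounds than this note shows. Statements on the series, on what has been measured and on what is new or still open speak of the compounds shown alone.

The series is followed in a functional assay on A549 cells (Homo sapiens) for cytotoxicity, read by MTT assay, with a stated time of 4 days; a higher number here means a weaker inhibitor, a lower number a stronger inhibitor. Compound 1, `C=C1C[C@]23C[C@@]1(O)CC[C@H]2c1cc(Br)c(O)c(C)c1[C@@H]3Cn1cc(-c2ccccc2)nn1`, gives only a limit there, > 20000 nM, and no number. Compound 2, `C=C1C(=O)[C@]23C[C@@]1(O)CC[C@H]2c1ccc(O)c(C)c1[C@@H]3Cn1cc(-c2ccc(C(F)(F)F)cc2)nn1`, gives 1110 nM, and compound 3, `C=C1C(=O)[C@]23C[C@@]1(O)CC[C@H]2c1ccc(O)c(C)c1[C@@H]3Cn1cc(-c2ccc(C)cc2)nn1`, gives 1260 nM. Going by the values given here, the single one-step comparison among them, a 1.1-fold higher number from compound 2 to compound 3 (0.06 log units; within the scatter), concerns the distal aromatic ring and leaves the two compounds within the scatter of each other; compound 3 therefore stands beside compound 2, with compound 1 set apart only by its limit, at the limit of > 20000 nM in this assay, at which 1 of the 3 values shown sits.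

Compound 4, `C=C1C(=O)[C@]23C[C@@]1(O)CC[C@H]2c1ccc(OS(=O)(=O)c2ccc(C)cc2)c(C)c1[C@@H]3Cn1cc(-c2ccc(C)cc2)nn1`, differs from compound 3 by (4-methylphenyl)sulfonyl in place of hydrogen on an oxygen on an aromatic ring. Among the compounds with values here, no measured step touches this oxygen: the step from compound 2 to compound 3 lies elsewhere, and compound 1 differs from compound 3 in several places at once, so its limit cannot be read as a single step. Within the data shown here, the expectation for compound 4 therefore rests on no direct precedent, and the step from compound 3 to compound 4 is estimated at a 1.7-fold higher number from compound 3 to compound 4 (0.24 log units; within the scatter), a modest weakening that could still fall within the scatter. In this assay compound 4 is thus expected to give about 2200 nM, within a range of 700 nM to 7000 nM.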

Compound 4, half-maximal inhibitory concentration: 1830 nM
The estimate for compound 4 lay 1.2-fold (0.08 log units) above the measured number; low and high end bracket the measured number.
By their numbers in this assay, from the lowest: compounds 2, 3 and 4 (each within the scatter of the next). At a limit, above all of these: compound 1.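

In this assay, going by these compounds alone, the hydroxy on the aromatic ring is replaced by ((4-methylphenyl)sulfonyl)oxy, giving a 1.5-fold higher number from compound 3 to compound 4 (0.16 log units; within the scatter); this is the first measured change at this oxygen, since the earlier one-step comparison concerned only the distal aromatic ring. The hydrogen on this oxygen can therefore give way to a group of 10 heavy atoms, including a further six-membered aromatic ring, with no change beyond the scatter, so a free hydroxy at this place is not required for a reading of this size in this series. The compounds shown offer no measurement that explains why this large substitution leaves the number within the scatter.

What the compounds shown leave open is how a smaller group on this oxygen, such as methyl or acetyl, or a chain ending in an amine or a carboxylic acid, would read in this assay. They also leave open whether the same replacement on compound 2, with its trifluoromethyl group in place of methyl on the distal ring, would again stay within the scatter.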